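This account rests on a few compounds, and the source may have more. Where it says the series, first, only, none or still open, it means among the compounds named here.

Compound 1, with the structure `CC(C#CCn1ccnc1)N1CCCC1=O`, was tested in a functional assay on the whole organism for agonist activity, with Mus musculus as the target; a lower number here means that less compound is needed, a higher number that more compound is needed for the effect. In this assay compound 1 gives only a limit, > 100 mg/kg. Compound 2, `Cc1cncn1CC#CC(C)N1CCCC1=O`, carries the change methyl in place of hydrogen on an aromatic carbon relative to compound 1. In this assay compound 2 likewise gives only a limit, > 100 mg/kg. The step from one to the other, a step that the two limits leave unreadable from compound 1 to compound 2, therefore cannot be sized, since both values sit at the limit of > 100 mg/kg in this assay, at which 2 of the 3 values shown sit, and nothing between them can be read.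

Compound 3, `CN(C)C(=O)N(C)CC#CCn1ccnc1`, has a different core from compound 1; how the two cores differ is not broken down here. In this assay, among the compounds with values here, compound 3 gives 11.8 mg/kg, the only value in this set that is a number rather than a limit.

Compound 4, `Cc1cncn1CC#CCN(C)C(=O)N(C)C`, has not been measured. Its difference from compound 3 is methyl in place of hydrogen on an aromatic carbon; this is the same change as that from compound 1 to compound 2, made on the core of compound 3 instead. Within the data shown here, because the only earlier example of this change sits at the limit of > 100 mg/kg in this assay, at which 2 of the 3 values shown sit, on both sides, it gives no reading of direction or size. Compound 4 is therefore expected to stand close to compound 3, with an estimated step of a 1.3-fold higher number from compound 3 to compound 4 (0.10 log units; within the scatter) in this assay, resting on compound 3 at 11.8 mg/kg alone. For compound 4 the estimate is 15 mg/kg, expected to fall between 5 mg/kg and 60 mg/kg.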

Compound 4, dose for half-maximal effect: 45.2 mg/kg
Compound 4: middle estimate off by 3.0-fold (0.48 log units), on the low side, within the range that was stated.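

Methyl in place of hydrogen on an aromatic carbon now has a readable size on the core of compound 3: in this assay it amounts to a 3.8-fold higher number from compound 3 to compound 4 (0.58 log units; beyond the scatter), so more compound is needed for the effect once the methyl is present. The same change on the core of compound 1 offers no size or direction to set beside this one, since compound 1 and compound 2 each give only a limit and the step between them cannot be read: the limit of > 100 mg/kg in this assay, at which 2 of the 4 values shown sit. The series therefore holds a single readable instance of this change, on one core, which shows what the methyl does there but does not show whether the step carries over from one core to another.

The compounds shown leave open whether the higher number is tied to methyl itself or would also appear with an ethyl group, a trifluoromethyl group or a chlorine atom at the same place on the core of compound 3. They also leave open whether a methyl on another aromatic carbon of the five-membered ring would give a step of similar size, and whether any such change would give a readable value on the core of compound 1.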